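Fluorine ortho to the nitrile: stability of compound 4

This account rests on a few compounds, and the source may have more. Where it says the series, first, only, none or still open, it means among the compounds named here.

Compound 3 `N#Cc1cccc(N/C(=N\O)c2nonc2SCCNC(=O)CS(N)(=O)=O)c1` carries a cyano group on the aryl ring. In an ADME assay on isolated protein for pharmacokinetics, with UDP-glucuronosyltransferase 1A9 (Homo sapiens) as the target, read by LC-MS, with a stated time of 60 min, at 37 degrees C, tested at 1 uM, in the presence of a further agent that is not named here (a lower number here means that the compound disappears faster, a higher number that the compound lasts longer), compound 3 reaches the limit of the assay at > 3 h. Of the three values shown, two sit at that limit (the limit of > 3 h in this assay, at which 2 of the 3 values shown sit). Compound 1 `NS(=O)(=O)CC(=O)NCCSc1nonc1/C(=N/O)Nc1cccc(C(F)F)c1`, with difluoromethyl in the same place, also gives a limit in this assay, > 3 h. Compound 2 `NS(=O)(=O)CC(=O)NCCSc1nonc1/C(=N/O)Nc1cccc(Cl)c1`, bearing chloro there, gives 0.9 h in this assay. The measured steps are an at least 3.3-fold lower number from compound 1 to compound 2 (0.52 log units; beyond the scatter), an at least 3.3-fold higher number from compound 2 to compound 3 (0.52 log units; beyond the scatter) and a step that the two limits leave unreadable from compound 1 to compound 3; all three swap the single substituent on the aryl ring, none adds a second one.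

Compound 4 `N#Cc1cc(N/C(=N\O)c2nonc2SCCNC(=O)CS(N)(=O)=O)ccc1F` differs from compound 3 by fluoro in place of hydrogen on an aromatic carbon; the place is ortho to a cyano group and para to a large group. Within the data shown here, no measured step covers an added fluoro, so no direction beyond the scatter is expected, and compound 4 is estimated to behave like compound 3, with the step from compound 3 to compound 4 expected at a step that the limit leaves unreadable from compound 3 to compound 4. Compound 4 is therefore expected to give about 3.5 h in this assay, within a range of 1.5 h to 8 h, most probably again only as a limit.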

Compound 4, half-life: > 3 h
Compound 4: only a limit was reported; the forecaster's own chance of this, stated with the estimate: 65%; the middle value does not contradict the limit.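

In this assay compound 4 gives > 3 h, a limit of the assay, so fluoro ortho to a cyano group and para to a large group leaves the compound at that limit. The 3-cyano-4-fluorophenyl group also stands clearly apart from 3-chlorophenyl, with an at least 3.3-fold higher number from compound 2 to compound 4 (0.52 log units; beyond the scatter). The steps to compound 4 from compound 3 and from compound 1 cannot be read because both ends of each are limits: the limit of > 3 h in this assay, at which 3 of the 4 values shown sit.

Going by these compounds, how far fluoro moves the half-life at this position therefore stays open. Also open, on these data alone, is how methoxy or trifluoromethyl would read at this place, and whether fluoro added to the 3-chlorophenyl group of compound 2, which gives 0.9 h, would shift a value that is not a limit.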